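From 3-methylphenyl to 3-ethylphenyl: an expected small step

The source may hold more compounds than are shown below. What is called first, only, known or untested is meant among the compounds shown, and "the series" means these compounds.

Measured in a functional assay on MDA-MB-231 cells (Homo sapiens) for antiproliferative activity, read by sulforhodamine B assay, with a stated time of 48 h; on this read-out lower numbers stand for stronger inhibition and higher numbers for weaker inhibition:
- compound 1 `O=C1NCCN1c1ccc(S(=O)(=O)Nc2ccc3[nH]ccc3c2)cc1`: 3600 nM
- compound 2 `Cc1cccc(NS(=O)(=O)c2ccc(N3CCNC3=O)cc2)c1`: 1270 nM

Compound 2 holds the lower of the two numbers at 1270 nM, while compound 1 stands higher at 3600 nM, a gap beyond the usual scatter. The next compound, compound 3 `CCc1cccc(NS(=O)(=O)c2ccc(N3CCNC3=O)cc2)c1`, has methyl in place of hydrogen on a saturated chain carbon bound to an aromatic carbon, which turns 3-methylphenyl into 3-ethylphenyl. Among the measured compounds shown here, no measured pair shows a change of this kind, so the data offer no direct guide to it. In this assay no step beyond the scatter is expected. The estimated change is a 1.2-fold lower number from compound 2 to compound 3 (0.06 log units; within the scatter). For compound 3 the estimate is 1100 nM, with an expected range from 450 nM to 2700 nM.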

Compound 3, half-maximal inhibitory concentration: 1410 nM
For compound 3 the middle estimate is 1.3-fold (0.11 log units) below the measured one, within the range that was stated.
By their numbers in this assay, from the lowest: compounds 2 and 3 (each within the scatter of the next); then compound 1.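

In this assay the move from 3-methylphenyl to 3-ethylphenyl gives a 1.1-fold higher number from compound 2 to compound 3 (0.05 log units; within the scatter) and so leaves the two compounds indistinguishable. Among the compounds shown here, this is the first pair that differs in one place, and it shows that methyl can enter on this saturated chain carbon bound to an aromatic carbon without a step beyond the scatter. No measurement at hand bears on why the two numbers stay so close.

For the compounds shown here, the pair covers only the step from methyl to ethyl, so it remains open whether a longer chain such as propyl or a branched group such as isopropyl would also stay within the scatter. As far as these compounds go, it is equally open how an amine or a carboxylic acid on this chain would read out in the same cells.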